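This account rests on a few compounds, and the source may have more. Where it says the series, first, only, none or still open, it means among the compounds named here.

Measured compounds in this assay:
compound 1, `O=C(O)c1ccccc1-c1ccc(CCc2ncc(Cc3ccccc3F)[nH]2)cc1`: 9.5 nM
compound 2, `O=C(O)c1ccccc1-c1ccc(CCc2ncc(CC3CCC3)[nH]2)cc1`: 7.1 nM
compound 3, `COc1ccccc1Cc1cnc(CCc2ccc(-c3ccccc3C(=O)O)cc2)[nH]1`: 163 nM

All three compounds share one core and differ only in the group on a saturated chain carbon bound to an aromatic carbon. In an in vitro functional assay on cells for agonist activity at Bombesin receptor subtype-3 (Mus musculus), read by luminescence and calcium flux (on this read-out lower numbers stand for an effect already at smaller amounts and higher numbers for an effect only at larger amounts of compound), compound 2 holds the lowest of the three numbers, but the step of a 1.3-fold lower number from compound 1 to compound 2 (0.13 log units; within the scatter) lies within the scatter, so compound 1 and compound 2 cannot be told apart. The step of a 23-fold higher number from compound 2 to compound 3 (1.36 log units; beyond the scatter), by contrast, is large, and the step of a 17-fold higher number from compound 1 to compound 3 (1.23 log units; beyond the scatter) is of the same kind.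

Compound 4, `N#Cc1cccc(Cc2cnc(CCc3ccc(-c4ccccc4C(=O)O)cc3)[nH]2)c1`, has not yet been measured. It differs from compound 2 by 3-cyanophenyl in place of cyclobutyl on a saturated chain carbon bound to an aromatic carbon. Going by the values given here, two measured steps bear on this change. The step of a 1.3-fold lower number from compound 1 to compound 2 (0.13 log units; within the scatter) shows that a phenyl ring with a small substituent and a cyclobutyl can give much the same number. The step of a 23-fold higher number from compound 2 to compound 3 (1.36 log units; beyond the scatter) shows that a phenyl ring with a different substituent can push the number far higher. Among the compounds with values here, no measured compound carries a nitrile, so the effect of that group is unknown. The expected outcome is therefore a moderate rise, a 2.8-fold higher number from compound 2 to compound 4 (0.45 log units; beyond the scatter), with wide uncertainty. Compound 4 is estimated at 20 nM, within a range of 5 nM to 80 nM.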

Compound 4, half-maximal effective concentration: 20 nM
Compound 4: middle estimate and measured number agree at the digits printed; the range from low to high includes it.
By their numbers in this assay, from the lowest: compounds 2 and 1 (each within the scatter of the next); then compound 4; then compound 3.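

In this assay, going by these compounds alone, 3-cyanophenyl puts a nitrile, with its triple bond and hydrogen-bond acceptor, on this saturated chain carbon for the first time, and putting it in place of cyclobutyl gives only a 2.8-fold higher number from compound 2 to compound 4 (0.45 log units; beyond the scatter) in a step rated modest. The other two phenyl groups set this result in context: changing 2-methoxyphenyl to 3-cyanophenyl gives an 8.2-fold lower number from compound 3 to compound 4 (0.91 log units; beyond the scatter) as a clear recovery, while changing 2-fluorophenyl to 3-cyanophenyl gives a 2.1-fold higher number from compound 1 to compound 4 (0.32 log units; beyond the scatter) as a small loss. Within the data shown here, a substituted phenyl ring at this position therefore does not bring a large rise on its own, since the large rise is seen only with 2-methoxyphenyl in compound 3, and the three phenyl compounds span a wide range that depends on what the ring carries.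

No measurement shown here explains any of these differences. Since the substituent and its ring position change together between these compounds, 2-cyanophenyl remains an open test of which matters, as do an amine or a carboxylic acid on the phenyl ring and a longer chain in place of cyclobutyl.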